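This account rests on a few compounds, and the source may have more. Where it says the series, first, only, none or still open, it means among the compounds named here.

The read-out here is an ADME assay on microsomes from liver (Homo sapiens) for metabolic stability, read by LC-MS, using NADPH, tested at 3 uM; on this read-out higher numbers stand for a longer-lived compound and lower numbers for a shorter-lived compound. Of the compounds shown here, three built on a shared core have been measured so far. Compound 1 `Cc1ccc2c(C(C(=O)C(F)(F)F)c3ccccc3)c(-c3ccccc3)[nH]c2c1` gives 4.45 h. Compound 2 `Cc1ccc2c(C(CC(F)(F)F)c3ccccc3)c(-c3ccccc3)[nH]c2c1` gives 1.45 h, and compound 3 `Cc1ccc2c(C(CC(F)(F)F)c3ccco3)c(-c3ccccc3)[nH]c2c1` gives 0.985 h. Among these, compound 2 holds the second highest number: its nearest neighbour is compound 3, within the usual scatter, and its furthest is compound 1, beyond it. The two steps that join the measured compounds are a 3.1-fold lower number from compound 1 to compound 2 (0.49 log units; beyond the scatter) and a 1.5-fold lower number from compound 2 to compound 3 (0.17 log units; within the scatter), both made by altering the chain attached to the core rather than the core itself.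

Compound 4 `FC(F)(F)CC(c1ccccc1)c1c(-c2ccccc2)[nH]c2cc(Cl)ccc12` changes something else. chloro in place of methyl on an aromatic carbon The methyl leaves and a chloro enters, on an aromatic carbon of a six-membered aromatic ring of carbon only, part of a fused or bridged system of two rings. Neither measured step touches that ring, so none of them bears directly on this change; they show only how far the numbers have moved within this small set. With nothing pointing in either direction, the expectation for compound 4 in this assay is a step of a 1.1-fold higher number from compound 2 to compound 4 (0.04 log units; within the scatter), that is none beyond the scatter. Compound 4 is therefore estimated at 1.6 h, with a range from 0.8 h to 3.2 h.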

Compound 4, half-life: 1.64 h
The estimate for compound 4 lay 1.0-fold (0.01 log units) below the measured number; the range from low to high includes it.
By their numbers in this assay, from the lowest: compounds 3, 2 and 4 (each within the scatter of the next); then compound 1.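

Of the steps shown, this is the only one made on a ring of the shared core and not on the chain. In this assay, chloro in place of methyl on this aromatic carbon, meta to a fused ring and para to a fused ring, gives a 1.1-fold higher number from compound 2 to compound 4 (0.05 log units; within the scatter) and so stays within the scatter, while the chain change in a 3.1-fold lower number from compound 1 to compound 2 (0.49 log units; beyond the scatter) goes beyond it. With the rest of compound 2 held as it is, this read-out therefore does not separate methyl from chloro at this position, and nothing measured here offers an explanation for that result.

From the compounds shown here alone, whether a larger or different group, such as methoxy, nitrile or an amine, would also leave the number within the scatter at this position remains open. Going by these compounds, it is also open whether chloro in place of methyl would give a similar step on the background of compound 1, with its (trifluoromethyl)carbonyl, or of compound 3, with its furan-2-yl, or at another carbon of the same ring.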